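A few compounds are considered here, and "the series" means these few. Any claim that something is new, unique, unknown or untested is made for them only; others in the source may bear on it.

Compound 1 `O=C1O/C(=C\Cn2cc(-c3ccc(Br)cc3)nn2)C(OCc2ccccc2)=C1OCc1ccccc1` and compound 2 `CC(C)(C)c1cn(C[C@H](O)[C@H]2OC(=O)C(OCc3ccccc3)=C2OCc2ccccc2)nn1` are the two compounds for which numbers exist, both tested in a functional assay on SW-620 cells (Homo sapiens) for antiproliferative activity, read by MTT assay, with a stated time of 72 h; a lower number here means a stronger inhibitor, a higher number a weaker inhibitor. For compound 1 the result in this assay is a limit, > 100000 nM, and not a number. Compound 2, built on a differently arranged version of the shared core, gives 35800 nM in this assay. Compound 1 thus stands at the weak end of what has been measured, as the limit of > 100000 nM in this assay, at which 1 of the 2 values shown sits, shows. Compound 3 `COc1ccccc1-c1cn(C/C=C2\OC(=O)C(OCc3ccccc3)=C2OCc2ccccc2)nn1` is the untested compound and differs from compound 1 in one place: 2-methoxyphenyl in place of 4-bromophenyl on an aromatic carbon of the five-membered aromatic ring with 3 nitrogen. Going by the values given here, no measured pair isolates this exchange, so there is no measured step to lean on. Since compound 1 sits at the limit described by the limit of > 100000 nM in this assay, at which 1 of the 2 values shown sits, any change is expected to be hard to see. The expected step of a number no higher from compound 1 to compound 3 (the limit leaves the size open) is no larger than the usual scatter, with no clear direction. Compound 3 is therefore expected at 100000 nM, with a range from 30000 nM to 300000 nM, most likely again reported only as a limit.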

Compound 3, half-maximal inhibitory concentration: > 100000 nM
Compound 3 ended at the assay's limit (the forecaster's own chance of this, stated with the estimate: 65%); the middle value lies on the limit itself.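

In this assay compound 3 gives > 100000 nM as a limit of the assay and not as a number. Compound 1 also stands only as a limit, so no step can be read between compound 1 and compound 3: the limit of > 100000 nM in this assay, at which 2 of the 3 values shown sit. The compounds shown leave open whether 2-methoxyphenyl in place of 4-bromophenyl on an aromatic carbon changes the activity at all.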